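Amine substituent variation on the shared pyrrolinone series

The compounds below may be only part of what the source reports. "The series", "measured", "known", "first", "only" and "open" are said of these compounds alone.

Measured so far:
compound 1 `O=C(C1=C(O)C(=O)N(CCCn2ccnc2)C1c1ccc(Br)cc1)c1ccccc1` — 31600 nM
compound 2 `O=C(C1=C(Nc2ccc(Br)cc2)C(=O)N(CCCn2ccnc2)C1c1ccc(Br)cc1)c1ccccc1` — 23800 nM

In a functional assay on SAOS-2 cells (Homo sapiens) for antiproliferative activity, read by MTT assay, with a stated time of 72 h (on this read-out higher numbers stand for weaker inhibition and lower numbers for stronger inhibition), compound 1 gives 31600 nM, and compound 2 gives 23800 nM. Among the measured compounds shown here, the single measured step, a 1.3-fold lower number from compound 1 to compound 2 (0.12 log units; within the scatter), replaces hydroxy with (4-bromophenyl)amino on the double-bonded ring carbon and stays within the scatter. Compound 2 therefore holds the lower of the two numbers, but its gap to compound 1 is within the scatter, so no order between them can be claimed.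

Compound 3 `O=C(C1=C(NCc2ccccc2)C(=O)N(CCCn2ccnc2)C1c1ccc(Br)cc1)c1ccccc1` is not yet measured. It differs from compound 2 in one place: benzyl in place of 4-bromophenyl on an amine nitrogen. For the measured compounds named here, no measured step changes this group; the only step at hand, from compound 1 to compound 2, altered the amine-bearing position itself and remained within the scatter. With nothing pointing to a move in either direction, the expectation for this assay is a step no larger than the scatter, a 1.1-fold higher number from compound 2 to compound 3 (0.02 log units; within the scatter). Compound 3 is estimated at 25000 nM, within 8000 nM to 80000 nM.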

Compound 3, half-maximal inhibitory concentration: 31600 nM
Beside the measured number, compound 3's estimate is 1.3-fold (0.10 log units) below it, and the stated range covers the measured number.
By their numbers in this assay, from the lowest: compounds 2, 1 and 3 (each within the scatter of the next).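

Within this assay, the first step on the amine substituent itself, a 1.3-fold higher number from compound 2 to compound 3 (0.12 log units; within the scatter), exchanges 4-bromophenyl for benzyl without separating the two compounds. The exchange of hydroxy for benzylamino on the double-bonded ring carbon gives no change at the digits printed from compound 1 to compound 3 (within the scatter), so a second amine at this place also cannot be told apart from the hydroxy compound. Hydroxy, (4-bromophenyl)amino and benzylamino therefore form a set of three with no order among them, and this series so far gives no handle on the number through this position. Nothing available bears on why these values sit together.

Open, as far as these compounds go, is whether any substituent at this place moves the number beyond the scatter, for instance a longer chain such as 2-phenylethylamino, a saturated ring such as cyclohexylamino or morpholine, or a basic side chain such as 2-(dimethylamino)ethylamino. Also open, from the compounds shown here alone, is whether the benzylamino result holds when the 4-bromophenyl on the shared core or the imidazole-bearing propyl chain is replaced, for example by a plain phenyl or a morpholine-bearing chain.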